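From phenyl to (pyridin-2-yl)methyl on compound 2

A few compounds are considered here, and "the series" means these few. Any claim that something is new, unique, unknown or untested is made for them only; others in the source may bear on it.

Compound 1 `O=C(NCc1cc(Cl)ccc1-n1cnnn1)[C@@H]1C[C@@H]2C[C@@H]2N1C(=O)[C@H](O)C1CCCCC1`: 16 10^-6 cm/s
Compound 2 `O=C(NCc1cc(Cl)ccc1-n1cnnn1)[C@@H]1C[C@@H]2C[C@@H]2N1C(=O)[C@H](O)c1ccccc1`: 8 10^-6 cm/s

Both compounds were measured in an ADME assay on Caco-2 cells (Homo sapiens) for permeability, read by LC-MS, in the apical to basolateral direction, with a stated time of 60 min, at pH 6.5; on this read-out higher numbers stand for higher permeability and lower numbers for lower permeability. There compound 2 gives 8 10^-6 cm/s, which lies within the usual scatter of compound 1 at 16 10^-6 cm/s, so the two numbers cannot really be told apart.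

Compound 3 `O=C(NCc1cc(Cl)ccc1-n1cnnn1)[C@@H]1C[C@@H]2C[C@@H]2N1C(=O)[C@H](O)Cc1ccccn1` keeps the shared core and alters one group: (pyridin-2-yl)methyl in place of phenyl on a saturated chain carbon bound to a carbonyl carbon and an oxygen on a saturated carbon. In words, (pyridin-2-yl)methyl stands in place of phenyl on a saturated chain carbon bound to a carbonyl carbon and an oxygen on a saturated carbon.

Among the measured compounds shown here, only one measured step touches this place: a 2.0-fold lower number from compound 1 to compound 2 (0.30 log units; within the scatter). That step exchanged cyclohexyl for phenyl and stayed within the scatter. For the measured compounds named here, no measured compound carries the (pyridin-2-yl)methyl group, so this step is an indirect guide and gives no direction. The expected change is a 1.1-fold lower number from compound 2 to compound 3 (0.06 log units; within the scatter), which would be no step beyond the scatter in this assay. Compound 3 is estimated at 7 10^-6 cm/s, with an expected range of 3 10^-6 cm/s to 16 10^-6 cm/s.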

Compound 3, apparent permeability: 1.2 10^-6 cm/s
Beside the measured number, compound 3's estimate is 5.8-fold (0.77 log units) above it; measured number outside the range, below it.
By their numbers in this assay, from the lowest: compound 3; then compounds 2 and 1 (each within the scatter of the next).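

In this assay this position now shows a clear response: the change to (pyridin-2-yl)methyl gives a 6.7-fold lower number from compound 2 to compound 3 (0.82 log units; beyond the scatter) and, set against cyclohexyl, a 13-fold lower number from compound 1 to compound 3 (1.12 log units; beyond the scatter). The earlier exchange of cyclohexyl for phenyl stayed within the scatter, so that step alone gave no sign that the group on this saturated chain carbon could move the number this far, whereas compound 3 now stands lowest of the three, beyond the scatter of both others. No measurement at hand explains why the number falls.

The entering group differs from phenyl in two ways at once, a methylene link and a ring nitrogen, and the compounds shown leave open which of the two goes with the lower number. A benzyl group, which has the link without the ring nitrogen, and a pyridin-2-yl group on the same carbon, which has the ring nitrogen without the link, would pull these two apart.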